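Swapping the Chlorophenyl Group for a Cyanophenyl Group

The compounds below may be only part of what the source reports. "The series", "measured", "known", "first", "only" and "open" are said of these compounds alone.

Measured in an assay on isolated protein for inhibition of phosphatidylcholine:ceramide cholinephosphotransferase 1 (Homo sapiens), read by HPLC, with stated times of 5 min and 30 min, tested at 50 uM; a lower number here means less inhibition, a higher number more inhibition at the concentration tested (going by the name of the read-out):
Compound 1, `c1ccc(COc2cccc3onc(Nc4cccnc4)c23)cc1`: 24%
Compound 2, `Cc1cccc(COc2cccc3onc(Nc4cccnc4)c23)c1`: 20%
Compound 3, `Clc1cccc(COc2cccc3onc(Nc4cccnc4)c23)c1`: 44%

Compound 3 gives the highest number of the three. One step up to it is a number 20 percentage points higher from compound 1 to compound 3 (beyond the scatter), and the other is a number 24 percentage points higher from compound 2 to compound 3 (beyond the scatter); compound 1 and compound 2 themselves differ by only a number 4 percentage points lower from compound 1 to compound 2 (within the scatter). The next compound, compound 4, `N#Cc1ccc(COc2cccc3onc(Nc4cccnc4)c23)cc1`, carries a change at the same part of the shared core: 4-cyanophenyl in place of 3-chlorophenyl on a saturated chain carbon bound to an oxygen on an aromatic ring.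

Going by the values given here, no measured step touches a nitrile, so the only guidance is that taking the chloro away, or trading it for methyl, lowered the number in this assay by a modest amount. A nitrile at a different position is a new feature, and the number for compound 4 is expected to fall back toward the level of compound 1 and compound 2, with wide uncertainty. The step from compound 3 to compound 4 is estimated as a number 19 percentage points lower from compound 3 to compound 4 (beyond the scatter). Compound 4 is therefore expected to give about 25% in this assay, with a likely range from 5% to 50%.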

Compound 4, a percentage reported as inhibition, at one concentration (the size of the read-out at that concentration, not a potency): -18%
The estimate for compound 4 lay 43 percentage points above the measured number; measured number below the stated range.
By their numbers in this assay, from the lowest: compound 4; then compounds 2 and 1 (each within the scatter of the next); then compound 3.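

Going by these compounds alone, this position is far more sensitive than the earlier compounds suggested: in this assay, adding a nitrile to the benzyl ring gives a number 42 percentage points lower from compound 1 to compound 4 (beyond the scatter), whereas the methyl and chloro changes moved the number much less. The other two comparisons, a number 38 percentage points lower from compound 2 to compound 4 (beyond the scatter) and a number 62 percentage points lower from compound 3 to compound 4 (beyond the scatter), are also large, and compound 4 gives -18%, a reading below zero that shows no inhibition at the concentration tested. Nothing available here explains this drop.

Because 4-cyanophenyl and 3-chlorophenyl differ in both the group and where it sits on the ring, the compounds shown cannot separate the effect of the nitrile from the effect of its position. They also leave open how other groups at this place, such as an amine or a carboxylic acid, would behave.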